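Pyridyl ethers of N-methylprolinol: chloro to ethyl

This account rests on a few compounds, and the source may have more. Where it says the series, first, only, none or still open, it means among the compounds named here.

Measured so far:
- compound 1 `CSc1ncccc1OC[C@@H]1CCCN1C`: 559 nM in an assay on membranes from brain for displacement of a labelled ligand from Neuronal acetylcholine receptor; alpha4/beta2 (Rattus norvegicus); a higher number here means a weaker inhibitor, a lower number a stronger inhibitor
- compound 2 `CN1CCC[C@H]1COc1cncc(Cl)c1`: 0.6 nM in this assay

Compound 2 holds the lowest of the two numbers; compound 1 sits far higher, beyond the scatter. Compound 3 `CCc1cncc(OC[C@@H]2CCCN2C)c1` differs from compound 2 by ethyl in place of chloro on an aromatic carbon. Within the data shown here, no measured pair shows this kind of exchange, so its size is open. A modest rise in the number is expected, since compound 2 already gives 0.6 nM and little room lies below it. The expected step is a 13-fold higher number from compound 2 to compound 3 (1.12 log units; beyond the scatter) in this assay. Compound 3 is estimated at 8 nM, within 2 nM to 40 nM.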

Compound 3, inhibition constant: 0.32 nM
The estimate for compound 3 lay 25-fold (1.40 log units) above the measured number, and the stated range ends above it.
By their numbers in this assay, from the lowest: compounds 3 and 2 (each within the scatter of the next); then compound 1.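

Ethyl in place of chloro on this aromatic carbon, two atoms from the ring nitrogen, gives a 1.9-fold lower number from compound 2 to compound 3 (0.27 log units; within the scatter) in this assay, so the two groups cannot be told apart in this assay. Among these compounds, the position therefore accepts an alkyl group as well as a halogen without a change beyond the scatter, which no earlier pair could show. Nothing measured on these compounds bears on why the two groups match.

From the compounds shown here alone, whether a longer chain such as butyl holds the number at this carbon remains open. So does the outcome with an amine or a carboxylic acid there.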